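Amino in Place of Azido: Compound 1 to Compound 4

This account rests on a few compounds, and the source may have more. Where it says the series, first, only, none or still open, it means among the compounds named here.

Compound 1 `[N-]=[N+]=NCC(O)Cn1c(=O)n(C2OC(CO)[C@@H](O)[C@H]2O)c2nc(N)nc(O)c21` gives 39 uM in a functional assay (B cells) with Mus musculus as the target; a higher number here means that more compound is needed for the effect, a lower number that less compound is needed.
Compound 2 `C=CCn1c(=O)n(C2OC(CO[Si](C)(C)C(C)(C)C)[C@@H](O)[C@H]2O)c2nc(N)nc(O)c21` gives 1 uM in this assay.
Compound 3 `C=CCn1c(=O)n(Cc2ccccc2)c2nc(N)nc(O)c21` gives 5 uM in this assay.

Among these three, compound 1 stands with the highest number, so it needs the most compound for the effect. Compound 3 lies nearest to it and compound 2 furthest, and both gaps are beyond the usual scatter. Compound 4 `NCC(O)Cn1c(=O)n(C2OC(CO)[C@@H](O)[C@H]2O)c2nc(N)nc(O)c21` is not yet measured; it differs from compound 1 in one place: amino in place of azido on a saturated chain carbon, two bonds along the chain from an oxygen on a saturated carbon. Among the compounds with values here, no measured pair shows this kind of change, so the size of the step is open. The change is small in atom count and keeps one hydrogen-bond acceptor while adding a donor, and no large shift in either direction is expected. For compound 4 the estimate in this assay is 40 uM, within 12 uM to 130 uM, which means an expected step of a 1.0-fold higher number from compound 1 to compound 4 (0.01 log units; within the scatter).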

Compound 4, concentration for half-maximal effect: 28 uM
Compound 4: the middle estimate sits 1.4-fold (0.15 log units) above what was measured; the range from low to high includes it.
By their numbers in this assay, from the lowest: compound 2; then compound 3; then compounds 4 and 1 (each within the scatter of the next).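

In this assay this swap gives a 1.4-fold lower number from compound 1 to compound 4 (0.14 log units; within the scatter) and so the chain end can carry amino in place of azido with no change that can be told from scatter. For this pair the azido group is therefore not needed to keep the effect at this level. Nothing at hand bears on why the two compounds read alike.

As far as these compounds go, whether a dimethylamino group, a hydroxyl or a carboxylic acid at the same place would shift the number stays open. So does whether the same swap on a longer chain would read alike.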